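This account rests on a few compounds, and the source may have more. Where it says the series, first, only, none or still open, it means among the compounds named here.

Measured so far: compound 1 `CCC1=C(O)c2c(oc(-c3ccc(OC)c(C)c3C)cc2=O)C(CC)(CC)C1=O` with 5.43 uM, compound 2 `CCC1=C(O)c2c(oc(-c3cc(OC)c(OC)c(OC)c3)cc2=O)C(CC)(CC)C1=O` with 46.7 uM, and compound 3 `CCC1=C(O)c2c(oc(-c3cccc(C)c3C)cc2=O)C(CC)(CC)C1=O` with 3.1 uM, all in a functional assay on KB cells (Homo sapiens) for antiproliferative activity, read by sulforhodamine B assay, with a stated time of 3 days; a higher number here means that more compound is needed for the effect, a lower number that less compound is needed.

The difference between the cores of compound 1 and compound 2 is not broken down here. From compound 1 to compound 3 the change is hydrogen in place of methoxy on an aromatic carbon, and it gave a 1.8-fold lower number from compound 1 to compound 3 (0.24 log units; within the scatter). Compound 2 gives the highest number of the three.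

Compound 4 `CCC1=C(O)c2c(oc(-c3cc(OC)cc(OC)c3)cc2=O)C(CC)(CC)C1=O` is not yet measured. It differs from compound 2 by hydrogen in place of methoxy on an aromatic carbon. This is the same kind of change as that from compound 1 to compound 3, but the surroundings differ: in compound 2 the site is ortho to two methoxy groups and para to a large group, whereas in compound 1 it is ortho to a methyl group, meta to a methyl group and para to a large group. Resting on a 1.8-fold lower number from compound 1 to compound 3 (0.24 log units; within the scatter), a similar small step is expected, a 1.9-fold lower number from compound 2 to compound 4 (0.27 log units; within the scatter). Compound 4 is therefore estimated at 25 uM, likely between 8 uM and 80 uM.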

Compound 4, concentration for half-maximal effect: 45.2 uM
Compound 4: the middle estimate sits 1.8-fold (0.26 log units) below what was measured; low and high end bracket the measured number.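

In this assay replacing methoxy with hydrogen on an aromatic carbon gave a 1.0-fold lower number from compound 2 to compound 4 (0.01 log units; within the scatter) and so left the number within the scatter on this core as well. Set beside the earlier case, the two steps do not differ: the same change on two cores in this assay, a 1.8-fold lower number (0.24 log units; within the scatter) from compound 1 to compound 3 and a 1.0-fold lower number (0.01 log units; within the scatter) from compound 2 to compound 4, 1.7-fold (0.23 log units) apart, within the scatter of two such steps. For the compounds shown here, this shows that the change carried from the core of compound 1 to the core of compound 2 without a detectable difference, but it rests on only two pairs and does not show that the same would hold on other cores or at other places on the ring.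

The compounds shown leave open whether another group at this place, such as an amine, a carboxylic acid or a longer chain, would move the number beyond the scatter.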